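The source may report more compounds than this note shows. Statements on the series, on what has been measured and on what is new or still open speak of the compounds shown alone.

Compound 1, `COc1ccc(OC)c(/C=C/C(=O)N/N=C/c2ccccc2)c1`: in a functional assay on DU-145 cells (Homo sapiens) for antiproliferative activity, read by sulforhodamine B assay, with a stated time of 48 h (on this read-out higher numbers stand for weaker inhibition of growth and lower numbers for stronger inhibition of growth), compound 1 gives "not determined" (no result reported).
Compound 2, `COc1ccc(OC)c(/C=C/c2nnc(Nc3ccc(Cl)cc3)o2)c1`: in this assay compound 2 gives 36900 nM.

Compound 1 therefore stands nowhere on the numbers shown: no single number for it exists in this assay, and the only measured value in the study belongs to compound 2, whose core differs from that of compound 1 and which cannot be tied to compound 1 by any counted step. The step under study goes from compound 1 to compound 3, `COc1ccc(OC)c(/C=C/C(=O)N/N=C/c2ccc(Cl)cc2)c1`. The change is small: chloro in place of hydrogen on an aromatic carbon. With no anchor for compound 1, the size of the step in this assay cannot be read from the data; a change of this kind is expected to move the value by no more than the scatter, in no settled direction. For the measured compounds named here, the one measured number, from compound 2 at 36900 nM, places a related dimethoxystyryl compound at the weak end of the scale, and compound 3 is expected to sit in the same region. Compound 3 is estimated at 30000 nM, with a range from 8000 nM to 100000 nM.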

Compound 3, concentration for total growth inhibition: 8400 nM
The estimate for compound 3 lay 3.6-fold (0.55 log units) above the measured number; the measured number falls inside the stated range.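

In this assay, for the compounds shown here, compound 3 gives 8400 nM but compound 1 has no single number, so no step from compound 1 to compound 3 can be read. From the compounds shown here alone, how phenyl to 4-chlorophenyl shifts growth inhibition on this scale therefore stays open. Nothing further shown bears on the value of compound 3.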